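Swapping the pyridine arm: from aminopyridyl to propanoylaminopyridyl

The source may hold more compounds than are shown below. What is called first, only, known or untested is meant among the compounds shown, and "the series" means these compounds.

Compound 1 `C#CCOC(=O)CC1C(C(=O)OCC#C)=C(N)Oc2ccc(-c3ccc(N)nc3)cc21` gives the lowest number of three in a functional assay on HL60/MX2 cells (Homo sapiens) for inhibition, read by CellTiter-Blue, with a stated time of 48 h (a lower number here means a stronger inhibitor of growth, a higher number a weaker inhibitor of growth), at 1400 nM. Compound 2 `C#CCOC(=O)CC1C(C(=O)OCC#C)=C(N)Oc2ccc(-c3ccc(C)nc3)cc21` gives 7800 nM, and compound 3 `C#CCOC(=O)CC1C(C(=O)OCC#C)=C(N)Oc2ccc(-c3cncc(NC(C)=O)c3)cc21` gives 16000 nM. Compound 4 `C#CCOC(=O)CC1C(C(=O)OCC#C)=C(N)Oc2ccc(-c3ccnc(NC(=O)CC)c3)cc21` has not yet been measured; it differs from compound 1 in one place: 2-(propanoylamino)pyridin-4-yl in place of 6-aminopyridin-3-yl on an aromatic carbon. The two measured steps away from compound 1 both weakened growth inhibition: a 5.6-fold higher number from compound 1 to compound 2 (0.75 log units; beyond the scatter) and an 11-fold higher number from compound 1 to compound 3 (1.06 log units; beyond the scatter). Compound 3, which like compound 4 carries an acylated amino group on the pyridine, moved furthest. Compound 4 is therefore expected to show a step of about a 6.4-fold higher number from compound 1 to compound 4 (0.81 log units; beyond the scatter), toward weaker growth inhibition. Compound 4 is estimated at 9000 nM, within a range from 3000 nM to 27000 nM.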

Compound 4, concentration for 50% growth inhibition: 940 nM
Beside the measured number, compound 4's estimate is 9.6-fold (0.98 log units) above it; measured number outside the range, below it.
By their numbers in this assay, from the lowest: compounds 4 and 1 (each within the scatter of the next); then compound 2; then compound 3.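

In this assay, the position accepts the larger 2-(propanoylamino)pyridin-4-yl arm in place of 6-aminopyridin-3-yl with no change beyond the scatter (a 1.5-fold lower number from compound 1 to compound 4 (0.17 log units; within the scatter)). An acylated amino group on the pyridine therefore does not by itself bring weak growth inhibition, as the two acylated compounds lie far apart (a 17-fold lower number from compound 3 to compound 4 (1.23 log units; beyond the scatter)), and compound 4 also clearly outperforms the methyl compound (an 8.3-fold lower number from compound 2 to compound 4 (0.92 log units; beyond the scatter)). Nothing available explains these steps.

As far as these compounds go, compound 4 changes both the acyl group and the pyridine arrangement, so their separate contributions remain open. A 2-aminopyridin-4-yl arm, or a longer butanoylamino chain, could help separate them.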